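Sulfonyl-linked anilides: pyridin-2-yl replacing 4-cyanophenyl

The source may hold more compounds than are shown below. What is called first, only, known or untested is meant among the compounds shown, and "the series" means these compounds.

Working notes on a small set of trifluoromethyl-bearing hydroxy-amides. Compound 1 `CC(O)(C(=O)Nc1ccc(C#N)c(Sc2ccccc2)c1)C(F)(F)F` gives 8300 nM in a functional assay (Cavia porcellus) with sulfonylurea receptors; K-ATP channels (Homo sapiens) as the target; a lower number here means a stronger inhibitor, a higher number a weaker inhibitor. Compound 2 `CC(O)(C(=O)Nc1ccc(S(=O)(=O)c2ccc(C#N)cc2)cc1)C(F)(F)F` carries a sulfonyl-linked aryl group instead of the sulfide of compound 1. In this assay compound 2 returns only a limit, > 30000 nM, with no number attached. Compound 2 thus sits at the limit of > 30000 nM in this assay, at which 1 of the 2 values shown sits, the weak end of the two values shown. Compound 3 `CC(O)(C(=O)Nc1ccc(S(=O)(=O)c2ccccn2)cc1)C(F)(F)F` is not yet measured; it differs from compound 2 by pyridin-2-yl in place of 4-cyanophenyl on a sulfonyl sulfur. For the measured compounds named here, no step between measured compounds covers this change, so only a rough expectation can be given. A step of about a number no higher from compound 2 to compound 3 (the limit leaves the size open) is expected, none beyond the scatter in either direction. Compound 3 is estimated at 30000 nM in this assay, within 10000 nM to 100000 nM, with a fair chance that only a limit is reported again.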

Compound 3, half-maximal inhibitory concentration: 600 nM
Compound 3: middle estimate off by 50-fold (1.70 log units), on the high side; measured number outside the range, below it.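

On a sulfonyl sulfur whose other neighbours are aromatic carbon, pyridin-2-yl in place of 4-cyanophenyl gives an at least 50-fold lower number from compound 2 to compound 3 (1.69 log units; beyond the scatter) in this assay. The group on this sulfonyl sulfur therefore has a large bearing on the read-out, and a sulfonyl-linked anilide can return a measured number in this assay rather than a limit. Compound 2 gives only a limit and not a number, so the full size of the step stays open: the limit of > 30000 nM in this assay, at which 1 of the 3 values shown sits.

This single change removes the nitrile and the carbon-only ring while bringing in a ring nitrogen, and the compounds shown do not tell these contributions apart. Plain phenyl on the sulfonyl sulfur would help to separate them, and pyridin-3-yl or pyridin-4-yl would test whether the place of the ring nitrogen matters.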